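Hydrazide series on K562 growth: outlook for compound 3

This account rests on a few compounds, and the source may have more. Where it says the series, first, only, none or still open, it means among the compounds named here.

Among the compounds with values here, compound 2 `O=C(NNC(=O)c1cc2ccccc2cc1O)c1ccc2[nH]c(-c3ccc([N+](=O)[O-])s3)nc2c1` stands at the highest of the two numbers so far in a functional assay on K562 cells (Homo sapiens) for inhibition, read by sulforhodamine B assay, with a stated time of 48 h; on this read-out lower numbers stand for stronger inhibition of growth and higher numbers for weaker inhibition of growth; in that assay compound 2 gives 31.3 ug/mL. Its nearest neighbour is compound 1 `COc1ccc(C(=O)NNC(=O)c2ccc3[nH]c(-c4ccc([N+](=O)[O-])o4)nc3c2)cc1OC`, for which this assay gives 15.6 ug/mL, a gap that lies within the scatter, so no order between the two can be drawn. Compound 1 differs from compound 3 in more than one place and offers no single-change comparison.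

Compound 3 `COc1cccc(C(=O)NNC(=O)c2ccc3[nH]c(-c4ccc([N+](=O)[O-])s4)nc3c2)c1` keeps the core of compound 2 and differs by 3-methoxyphenyl in place of 3-hydroxynaphthalen-2-yl on a carbonyl carbon. Within the data shown here, no measured pair shows this change on its own, so its effect in this assay is unknown. The expected step is a 1.4-fold lower number from compound 2 to compound 3 (0.15 log units; within the scatter), a modest move toward a lower number that need not exceed the scatter. Compound 3 is therefore estimated at 22 ug/mL, with a plausible range from 8 ug/mL to 55 ug/mL.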

Compound 3, concentration for 50% growth inhibition: 15.6 ug/mL
Compound 3: the middle estimate sits 1.4-fold (0.15 log units) above what was measured; the measured number falls inside the stated range.
By their numbers in this assay, from the lowest: compounds 1, 3 and 2 (each within the scatter of the next).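

Within the data shown here, replacing 3-hydroxynaphthalen-2-yl with 3-methoxyphenyl on a carbonyl carbon gives, in this assay, a 2.0-fold lower number from compound 2 to compound 3 (0.30 log units; within the scatter) and so sets no order between the pair. Among these compounds, this is the first single-change reading at this place: one of the two six-membered aromatic rings and the hydrogen-bond donor leave with the entering group, and the two numbers remain within the scatter of each other. No measured evidence on any property bears on this result.

Going by these compounds, whether an amine or a carboxylic acid in place of 3-methoxyphenyl on that carbonyl carbon would give a step beyond the scatter remains open. Also open, on these data alone, is whether the same change would read alike on the core of compound 1.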